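Swapping the Triazole Substituent in a GnRH Antagonist Series

The source may report more compounds than this note shows. Statements on the series, on what has been measured and on what is new or still open speak of the compounds shown alone.

Of the compounds shown here, three sharing one core have been measured in a functional assay on cells for antagonist activity at Gonadotropin-releasing hormone receptor (Homo sapiens), read by FLIPR and calcium flux, with a stated time of 15 min; a higher number here means a weaker inhibitor, a lower number a stronger inhibitor. Compound 1 `CC(C)(C)c1ccc(-c2nc3c(N4CCN(Cc5cccc6nccnc56)CC4)cccc3[nH]2)cc1` gives 631 nM, and compound 2 `C#CCN1CCN(c2cccc3[nH]c(-c4ccc(C(C)(C)C)cc4)nc23)CC1` gives 20000 nM; that pair shows a 32-fold higher number from compound 1 to compound 2 (1.50 log units; beyond the scatter). Compound 3 `CC(C)(C)c1ccc(-c2nc3c(N4CCN(Cc5cn(-c6nc7ccccc7[nH]6)nn5)CC4)cccc3[nH]2)cc1` gives 5010 nM, standing second highest of the three numbers, clearly above compound 1 and clearly below compound 2. Compound 4 `CC(C)(C)c1ccc(-c2nc3c(N4CCN(Cc5cn(-c6ccc(F)cc6)nn5)CC4)cccc3[nH]2)cc1` differs from compound 3 by 4-fluorophenyl in place of 1H-benzimidazol-2-yl on an aromatic nitrogen. Within the data shown here, no measured pair covers this exact change; the only measured step removes an aromatic group entirely, whereas here one aromatic group replaces another. A step of modest size is therefore expected, a 1.7-fold lower number from compound 3 to compound 4 (0.22 log units; within the scatter), with the direction uncertain. Compound 4 is estimated at 3000 nM, within a range of 1000 nM to 10000 nM.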

Compound 4, half-maximal inhibitory concentration: 20000 nM
Estimate against measurement, compound 4: 6.7-fold (0.82 log units) below; the measured number lies above the stated range.
By their numbers in this assay, from the lowest: compound 1; then compound 3; then compounds 2 and 4 (each within the scatter of the next).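

On this aromatic nitrogen the choice of aromatic group matters: 4-fluorophenyl in place of 1H-benzimidazol-2-yl gives a 4.0-fold higher number from compound 3 to compound 4 (0.60 log units; beyond the scatter) and so leaves the number far from that of compound 1. The whole 1-(4-fluorophenyl)-1H-1,2,3-triazol-4-yl group offers no gain over ethynyl, with no change at the digits printed from compound 2 to compound 4 (within the scatter) and, against quinoxalin-5-yl, a 32-fold higher number from compound 1 to compound 4 (1.50 log units; beyond the scatter) on the same chain carbon. Nothing available here explains these steps. Still open, as far as these compounds go, is whether an amine or a carboxylic acid in place of the fluorine on that phenyl ring would lower the number.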